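The source may hold more compounds than are shown below. What is called first, only, known or untested is meant among the compounds shown, and "the series" means these compounds.

Among the compounds with values here, compound 1 (`CCOc1cc(NC(=O)CCCCCC(=O)Nc2cc(-c3ccccc3)ccc2N)cc2c1OCC([N+](=O)[O-])=C2`) and compound 2 (`CCOc1cc(NC(=O)CCCCCCC(=O)Nc2cc(-c3ccccc3)ccc2N)cc2c1OCC([N+](=O)[O-])=C2`) are the two compounds measured so far. In a functional assay on HeLa cells (Homo sapiens) for antiproliferative activity, read by MTT assay, with a stated time of 48 h (a lower number here means a stronger inhibitor of growth, a higher number a weaker inhibitor of growth), compound 1 gives 19800 nM and compound 2 gives 16200 nM. These two values lie within the scatter of each other, so compound 2 stands level with compound 1 and neither can be ranked ahead.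

The account now turns to compound 3 (`CCOc1cc(NC(=O)CCCCCCC(=O)Nc2ccccc2N)cc2c1OCC([N+](=O)[O-])=C2`), which departs from compound 2 at a single place: hydrogen in place of phenyl on an aromatic carbon. Hydrogen takes the place of phenyl on an aromatic carbon, para to an amino group. Within the data shown here, no measured pair carries this change, so the data offer no direct guide to its size or direction. The expectation therefore rests only on compound 2 at 16200 nM, and no step beyond the scatter is expected in this assay, with either direction left open. The expected step of a 1.1-fold higher number from compound 2 to compound 3 (0.05 log units; within the scatter) is small. In this assay the estimate for compound 3 is 18000 nM, with an expected range from 7000 nM to 45000 nM.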

Compound 3, concentration for 50% growth inhibition: > 20000 nM
Compound 3: no number, only a limit (the forecaster's own chance of this, stated with the estimate: 10%); middle value at least 1.1-fold (0.04 log units) from the limit.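

In this assay compound 3 gives > 20000 nM, which is a limit of the assay and not a number. Hydrogen in place of phenyl on this aromatic carbon, para to an amino group, now has its first reading, and it comes only as a floor: an at least 1.2-fold higher number from compound 2 to compound 3 (0.09 log units; that floor lies within the scatter). That floor does not separate the two compounds, so the result cannot say how much the phenyl at this position contributes to growth inhibition, because compound 3 carries a limit and not a value that could fix the size of the step: the limit of > 20000 nM in this assay, at which 1 of the 3 values shown sits.

The compounds shown leave open how other groups on this same carbon would read in this assay, such as a thienyl ring, a methoxy group or a fluorine atom, any of which could show whether the position responds to a substituent at all. They also leave open whether hydrogen in place of phenyl would read the same way on the chain of compound 1, and what the size of the step from compound 2 really is.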